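A (1,4-diazepan-1-yl)carbonyl replaces cyclopropylsulfonyl on compound 2

The source may hold more compounds than are shown below. What is called first, only, known or untested is meant among the compounds shown, and "the series" means these compounds.

Compound 1 `CCCS(=O)(=O)Nc1ccc(-c2cc(=O)c3c(O)cc(OC)c(OC(C)C)c3o2)cc1`: 30500 nM
Compound 2 `COc1cc(O)c2c(=O)cc(-c3ccc(NS(=O)(=O)C4CC4)cc3)oc2c1OC(C)C`: 8800 nM

In a functional assay on LNCaP cells (Homo sapiens) for antiproliferative activity, read by MTT assay, with a stated time of 3 days (on this read-out lower numbers stand for stronger inhibition and higher numbers for weaker inhibition), compound 2 has the lower of the two numbers, 8800 nM. Compound 3 `COc1cc(O)c2c(=O)cc(-c3ccc(NC(=O)N4CCCNCC4)cc3)oc2c1OC(C)C` differs from compound 2 as follows: (1,4-diazepan-1-yl)carbonyl in place of cyclopropylsulfonyl on a nitrogen on an aromatic ring. Among the compounds with values here, the only measured step that bears on this is a 3.5-fold lower number from compound 1 to compound 2 (0.54 log units; beyond the scatter), a modest change at the group on the sulfonyl sulfur, whereas here the whole cyclopropylsulfonyl leaves. That step gives no direction for the entering group, so no change beyond the scatter is expected. The estimated step is a 1.8-fold lower number from compound 2 to compound 3 (0.25 log units; within the scatter). For compound 3 the expected value is 5000 nM, with an estimated range of 1300 nM to 20000 nM.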

Compound 3, half-maximal inhibitory concentration: 22500 nM
Compound 3: middle estimate off by 4.5-fold (0.65 log units), on the low side; the measured number lies above the stated range.
By their numbers in this assay, from the lowest: compound 2; then compounds 3 and 1 (each within the scatter of the next).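

In this assay, the sulfonyl group on this nitrogen is not needed for a measurable read-out, yet its exchange for (1,4-diazepan-1-yl)carbonyl gives a 2.6-fold higher number from compound 2 to compound 3 (0.41 log units; beyond the scatter) and so loses ground against the cyclopropylsulfonyl group. Against the propylsulfonyl group, the same exchange gives a 1.4-fold lower number from compound 1 to compound 3 (0.13 log units; within the scatter) and leaves compound 3 and compound 1 not told apart. No measurement here explains either step.

From the compounds shown here alone, whether the loss lies with the carbonyl, the seven-membered ring or its ring amine stays open. A piperazine or a plain acetyl group on this nitrogen could help separate these.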